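Acetyl in Place of Ethyl: An Expected Number

The source may report more compounds than this note shows. Statements on the series, on what has been measured and on what is new or still open speak of the compounds shown alone.

Of the compounds shown here, three sharing one core have been measured in an ADME assay on the whole organism with Oryza sativa as the target, tested at 10 uM; on this read-out higher numbers stand for a weaker effect at the one concentration tested and lower numbers for a stronger effect. Compound 1 `CCc1ccccc1NC(=O)N[C@H](C)c1ccccc1` gives 92%. Compound 2 `CCc1ccccc1NC(=O)N[C@@H](C)c1ccccc1` gives 95%, and compound 3 `CCCCCc1ccc(NC(=O)N[C@@H](C)c2ccccc2)cc1` gives 93%. The number of compound 2 stands at the top of the three, nearest that of compound 3 and furthest from that of compound 1, yet both gaps fall within the scatter, so all three read as one weak effect at the single concentration tested. Within the data shown here, the only measured step, a number 3 percentage points higher from compound 1 to compound 2 (within the scatter), stays within the scatter and rests on (the fact that compounds 1 and 2 differ only in the configuration as drawn).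

Compound 4 `CC(=O)c1ccccc1NC(=O)N[C@@H](C)c1ccccc1` has not yet been measured. It differs from compound 2 by acetyl in place of ethyl on an aromatic carbon. Among the measured compounds shown here, no measured step replaces one group with another at an aromatic carbon, so nothing here points to a change beyond the scatter; the expected step is a number 2 percentage points lower from compound 2 to compound 4 (within the scatter). For compound 4 the estimated value in this assay is therefore 93%, expected to fall between 86% and 98%.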

Compound 4, a percentage reported as activity, at one concentration (the size of the read-out at that concentration, not a potency): 96%
Compound 4: middle estimate off by 3 percentage points, on the low side; measured number inside the range.
By their numbers in this assay, from the lowest: compounds 1, 3, 2 and 4 (each within the scatter of the next).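

Among the earlier compounds, no step replaced one group with another at an aromatic carbon; this one does, and in this assay acetyl in place of ethyl gives a number 1 percentage points higher from compound 2 to compound 4 (within the scatter) for this swap. The change adds a carbonyl oxygen, counted as a hydrogen-bond acceptor, on an aromatic carbon ortho to a large group, and the read-out stays level with that of the other three compounds. Nothing available bears on why this swap leaves the number unmoved beyond the scatter.

The compounds shown leave open whether a group of another kind at this position, such as an amine or a carboxylic acid, would give a step beyond the scatter. They also leave open whether acetyl would read the same with the configuration drawn in compound 1.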